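Bromophenyl position shift on a shared core

This account rests on a few compounds, and the source may have more. Where it says the series, first, only, none or still open, it means among the compounds named here.

Of the compounds shown here, three of one shared core have been measured in a functional assay on CHO cells for agonist activity at adenosine receptor A1 (Homo sapiens), read by fluorescence and ERK phosphorylation, with stated times of 30 min and 1.5 h, tested at 3 uM (a higher number here means a stronger effect of the compound at the concentration tested, a lower number a weaker effect), a fourth has not. Compound 1 `Nc1scc(-c2cccc(Br)c2)c1C(=O)c1ccccc1` gives 67% in this assay. Compound 2 `Nc1scc(-c2ccc(Br)cc2)c1C(=O)c1ccccc1` differs from compound 1 by 4-bromophenyl in place of 3-bromophenyl on an aromatic carbon; in this assay compound 2 gives 46%, and the step is a number 21 percentage points lower from compound 1 to compound 2 (beyond the scatter). Compound 3 `Nc1scc(-c2cccc(Br)c2)c1C(=O)c1ccc(Cl)cc1` differs from compound 1 by chloro in place of hydrogen on an aromatic carbon; in this assay compound 3 gives 62%, a step of a number 5 percentage points lower from compound 1 to compound 3 (within the scatter), so the chloro leaves the read-out where it was. Compound 4 `Nc1scc(-c2ccc(Br)cc2)c1C(=O)c1ccc(Cl)cc1` is not yet measured and differs from compound 3 by 4-bromophenyl in place of 3-bromophenyl on an aromatic carbon. The surroundings of the place are not identical in the two cases: in compound 1 the neighbouring ring atom bears a group of 8 heavy atoms, in compound 3 a group of 9 heavy atoms, so the change from compound 3 to compound 4 is the same kind of change as that from compound 1 to compound 2, not the same change.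

For the measured compounds named here, since compound 3 sits close to compound 1, as the step of a number 5 percentage points lower from compound 1 to compound 3 (within the scatter) shows, the bromophenyl shift is expected to cost about as much again, a step estimated at a number 20 percentage points lower from compound 3 to compound 4 (beyond the scatter), resting on the single earlier instance a number 21 percentage points lower from compound 1 to compound 2 (beyond the scatter). Going by the values given here, compound 4 is therefore expected to give about 42% in this assay, estimated between 28% and 56%; with only one prior example the range is kept wide.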

Compound 4, a percentage reported as activity, at one concentration (the size of the read-out at that concentration, not a potency): 45%
Compound 4: the middle estimate sits 3 percentage points below what was measured; the range from low to high includes it.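

The shift from 3-bromophenyl to 4-bromophenyl carries over to the core bearing the chloro in this assay, with a number 17 percentage points lower from compound 3 to compound 4 (beyond the scatter), and it matches the earlier step on the core of compound 1: the same change on two cores in this assay, a number 21 percentage points lower (beyond the scatter) from compound 1 to compound 2 and a number 17 percentage points lower (beyond the scatter) from compound 3 to compound 4, 4 percentage points apart, within the scatter of two such steps. The chloro in place of hydrogen also behaves alike on both bromophenyl isomers, with a number 1 percentage points lower from compound 2 to compound 4 (within the scatter), so within these compounds the read-out follows the bromine position and stays with it whichever benzoyl-side group is present: the same change on two cores in this assay, a number 5 percentage points lower (within the scatter) from compound 1 to compound 3 and a number 1 percentage points lower (within the scatter) from compound 2 to compound 4, 4 percentage points apart, within the scatter of two such steps. This rests on two pairs of cores that differ by a single chloro, read at one concentration, so it shows transfer of the change across these cores only; it gives no potency and does not show that the step would hold on a core changed elsewhere.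

The compounds shown leave open whether the step belongs to bromine or to the ring position as such, which a methoxy or a nitrile on the same phenyl ring would help to separate. Also open, from the compounds shown here alone, is whether the step survives on cores where the amino group gives way to an amide or the ketone-linked phenyl carries a carboxylic acid.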